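The source may hold more compounds than are shown below. What is called first, only, known or untested is meant among the compounds shown, and "the series" means these compounds.

Of the compounds shown here, three have so far been measured in a functional assay on L6 cells (Rattus norvegicus) for inhibition; on this read-out higher numbers stand for weaker inhibition and lower numbers for stronger inhibition. Compound 1 `Cc1ccc(CNC(=O)c2nn(-c3ccc(F)cc3)c(CC[C@@H](O)C[C@@H](O)CC(=O)O)c2C(C)C)cc1` gives 800 nM, and compound 2 `CC(C)c1c(C(=O)N2CCC[C@H](N3CCC4C=CC=CC4C3)C2)nn(-c2ccc(F)cc2)c1CC[C@@H](O)C[C@@H](O)CC(=O)O` gives 1720 nM. Compound 3 `CC(C)c1c(C(=O)N2CCCCC2)nn(-c2ccc(F)cc2)c1OC[C@@H](O)C[C@@H](O)CC(=O)O` gives 32200 nM, the highest of the three numbers; the other two values lie far below it, beyond the scatter. Compound 4 `Cc1cccc(CN(C)C(=O)c2nn(-c3ccc(F)cc3)c(OC[C@@H](O)C[C@@H](O)CC(=O)O)c2C(C)C)c1` differs from compound 3 in one place: methyl(3-methylbenzyl)amino in place of piperidin-1-yl on a carbonyl carbon. Among the measured compounds shown here, no step between measured compounds covers this change, and compounds 1 and 2 differ from compound 3 in more than this one place, so their values show only where they stand. A moderate downward step in this assay is expected, a 3.2-fold lower number from compound 3 to compound 4 (0.51 log units; beyond the scatter), though with considerable uncertainty. Compound 4 is estimated at 10000 nM, with a range from 2500 nM to 40000 nM.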

Compound 4, half-maximal inhibitory concentration: 18500 nM
Compound 4: the middle estimate sits 1.9-fold (0.27 log units) below what was measured, and the stated range covers the measured number.
By their numbers in this assay, from the lowest: compound 1; then compound 2; then compounds 4 and 3 (each within the scatter of the next).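

In this assay, methyl(3-methylbenzyl)amino in place of piperidin-1-yl on a carbonyl carbon gives a 1.7-fold lower number from compound 3 to compound 4 (0.24 log units; within the scatter). At this place, then, a six-membered aromatic ring of carbon only, carried on the larger group, leaves the read-out unchanged within the scatter where a six-membered non-aromatic ring stood before. No evidence at hand bears on this result. From the compounds shown here alone, what a morpholin-4-yl or a pyrrolidin-1-yl group on the same carbonyl carbon would give stays open. So does the part played by each of the two methyl groups of the entering group.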